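Ester to amide on a weak aorta series

The compounds below may be only part of what the source reports. "The series", "measured", "known", "first", "only" and "open" are said of these compounds alone.

Compound 2 `CCOC(=O)CCN(c1ccccc1)[C@H]1c2cc(C#N)ccc2OC(C)(C)[C@@H]1O`: 54000 nM
Compound 1 `CCOC(=O)CN(c1ccccc1)[C@@H]1c2cc(C#N)ccc2OC(C)(C)[C@H]1O`: > 30000 nM

Of the compounds shown here, two share one core and have been tested in a functional assay (aorta) with Rattus norvegicus as the target; on this read-out higher numbers stand for weaker inhibition and lower numbers for stronger inhibition. Going by the values given here, compound 2 is the only one with a number: in this assay compound 2 gives 54000 nM, a very weak inhibition. Compound 1 does not even reach a number; in this assay compound 1 reports only a limit of > 30000 nM, which means inhibition was too weak to be measured there (the limit of > 30000 nM in this assay, at which 1 of the 2 values shown sits). Among the compounds with values here, no step between the two can be computed, so their values show only that both sit at the weak end.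

Compound 3 `CCNC(=O)CN(c1ccccc1)[C@H]1c2cc(C#N)ccc2OC(C)(C)[C@@H]1O` has not yet been measured. It differs from compound 2 by ethylcarbamoyl in place of (ethoxycarbonyl)methyl on a saturated chain carbon bound to a nitrogen on an aromatic ring. Nothing in the shown numbers tells how far such a change moves the read-out in this assay, so the step from compound 2 to compound 3 is expected to stay within the usual scatter, a 1.2-fold lower number from compound 2 to compound 3 (0.08 log units; within the scatter), with a real chance that only a limit is reported. Compound 3 is therefore expected to give about 45000 nM in this assay, within 12000 nM to 150000 nM.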

Compound 3, half-maximal inhibitory concentration: > 30000 nM
Compound 3: only a limit was reported; the forecaster's own chance of this, stated with the estimate: 50%; the middle value is on the limit's open side.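

In this assay compound 3 gives only a limit, > 30000 nM. Going by these compounds alone, no step from compound 2 to compound 3 can be read, because that result is not a number: the limit of > 30000 nM in this assay, at which 2 of the 3 values shown sit. The compounds shown leave open whether ethylcarbamoyl in place of (ethoxycarbonyl)methyl changes inhibition at all, and in which direction.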